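A few compounds are considered here, and "the series" means these few. Any claim that something is new, unique, unknown or untested is made for them only; others in the source may bear on it.

In an in vitro ADME assay on microsomes from liver (Mus musculus) for pharmacokinetics, read by LC-MS, with a stated time of 10 min, tested at 1 uM (on this read-out higher numbers stand for fast clearance and lower numbers for slow clearance), compound 1 `CN1C[C@H](C(=O)Nc2ccc(F)cc2)[C@@H](c2ccc(/C=C/C(=O)Nc3ccccc3N)cc2)C1` gives 34 mL/min/kg, while compound 2 `CN1C[C@H](C(=O)Nc2ccc(Br)cc2)[C@@H](c2ccc(/C=C/C(=O)Nc3ccccc3N)cc2)C1` gives 16 mL/min/kg, a change of a 2.1-fold lower number from compound 1 to compound 2 (0.33 log units; beyond the scatter). Compound 2 therefore stands lowest of the two numbers shown. Compound 3 `Cc1cc(NC(=O)[C@H]2CN(C)C[C@@H]2c2ccc(/C=C/C(=O)Nc3ccccc3N)cc2)ccc1F` differs from compound 2 by 4-fluoro-3-methylphenyl in place of 4-bromophenyl on an amide-type nitrogen. Within the data shown here, only one measured step bears on this change, and it ran the opposite way, with the fluoro compound giving the higher number of the pair. A partial return toward the value of compound 1 is expected, the added methyl leaving the outcome uncertain. Compound 3 is thus estimated at 25 mL/min/kg, within 12 mL/min/kg to 50 mL/min/kg. This amounts to an expected step of a 1.6-fold higher number from compound 2 to compound 3 (0.19 log units; within the scatter).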

Compound 3, clearance: 62 mL/min/kg
Beside the measured number, compound 3's estimate is 2.5-fold (0.39 log units) below it, and the stated range ends below it.
By their numbers in this assay, from the lowest: compound 2; then compounds 1 and 3 (each within the scatter of the next).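

In this assay, 4-fluoro-3-methylphenyl in place of 4-bromophenyl on the amide-type nitrogen gives a 3.9-fold higher number from compound 2 to compound 3 (0.59 log units; beyond the scatter), so the low number of compound 2 is not kept with this group. Methyl in place of hydrogen on an aromatic carbon gives a 1.8-fold higher number from compound 1 to compound 3 (0.26 log units; within the scatter), which leaves both fluorine-bearing compounds apart from the bromine-bearing compound 2 and the methyl without a readable effect. Nothing shown gives a reason for these steps. Still open, as far as these compounds go, is whether 4-chlorophenyl at this position would stand with compound 2 or with the fluorine-bearing pair. Also open, from the compounds shown here alone, is whether 4-bromo-3-methylphenyl would keep the number of compound 2.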